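A Furan Ring Replaces Bromophenyl on the Chain

A few compounds are considered here, and "the series" means these few. Any claim that something is new, unique, unknown or untested is made for them only; others in the source may bear on it.

Among the compounds with values here, compound 2 `CC1=C(/C=C/C(=O)/C=C/c2ccccc2Br)C(C)(C)CCC1` is one of two compounds measured in a functional assay on MCF7 cells (Homo sapiens) for cytotoxicity, read by sulforhodamine B assay, with a stated time of 48 h; on this read-out higher numbers stand for weaker inhibition and lower numbers for stronger inhibition. In this assay compound 2 gives 20700 nM, the higher of the two numbers; its only comparator, compound 1 `CC1=C(/C=C/C(=O)/C=C/c2ccc(F)cc2)C(C)(C)CCC1`, gives 6200 nM in this assay. Within the data shown here, the single step measured so far, a 3.3-fold higher number from compound 1 to compound 2 (0.52 log units; beyond the scatter), shows that exchanging one aromatic group for another at this end of the chain can move the number by a modest amount. Compound 3 `CC1=C(/C=C/C(=O)/C=C/c2ccoc2)C(C)(C)CCC1` differs from compound 2 at exactly that position: furan-3-yl in place of 2-bromophenyl on a double-bonded chain carbon bound to a double-bonded chain carbon. Among the measured compounds shown here, no measured step involves a furan, so the step from 4-fluorophenyl to 2-bromophenyl is the only guide, and it suggests a modest shift in either direction. For compound 3 a step of about a 1.7-fold lower number from compound 2 to compound 3 (0.24 log units; within the scatter) is therefore expected, a shift that stays within the scatter. The estimate for compound 3 in this assay is 12000 nM, with a range from 3500 nM to 40000 nM.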

Compound 3, half-maximal inhibitory concentration: 100000 nM
For compound 3 the middle estimate is 8.3-fold (0.92 log units) below the measured one; measured number above the stated range.
By their numbers in this assay, from the lowest: compound 1; then compound 2; then compound 3.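

In this assay, furan-3-yl gives a higher number, meaning weaker inhibition, than either halogen-bearing phenyl group at this place on the chain (a 4.8-fold higher number from compound 2 to compound 3 (0.68 log units; beyond the scatter)) and (a 16-fold higher number from compound 1 to compound 3 (1.21 log units; beyond the scatter)). The earlier step showed only a modest change between two phenyl groups, whereas the three aromatic groups now span a large range, so this position is more sensitive to the choice of ring than compounds 1 and 2 alone could show. No measured evidence here explains the effect of this ring change.

Going by these compounds, it remains open whether the furan oxygen or the change from a six-membered to a five-membered ring matters more. It is also unknown where an unsubstituted phenyl, a furan-2-yl or a phenyl ring carrying an amine or a carboxylic acid would fall.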